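The source may hold more compounds than are shown below. What is called first, only, known or untested is meant among the compounds shown, and "the series" means these compounds.

Measured in a functional assay on U-251 cells (Homo sapiens) for cytotoxicity; a lower number here means a stronger inhibitor of growth, a higher number a weaker inhibitor of growth:
- Compound 1 `CSc1ccc(C2=C(c3ccc(OCC4CO4)cc3)C(=O)N3CCCC3C2)cc1`: 80 nM
- Compound 2 `CSc1ccc(C2=C(c3ccc(C)cc3)C(=O)N3CCCC3C2)cc1`: 400 nM

Of these two compounds, compound 2 has the higher number, so it is the weaker inhibitor of growth in this assay. The next compound to consider is compound 3 `CSc1ccc(C2=C(c3ccc(C(F)(F)F)cc3)C(=O)N3CCCC3C2)cc1`, which keeps the shared core and changes one group: trifluoromethyl in place of methyl on an aromatic carbon. Here trifluoromethyl takes the place of methyl on an aromatic carbon, para to a large group.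

For the measured compounds named here, only one measured step bears on this change. Going the other way at this carbon, a 5.0-fold higher number from compound 1 to compound 2 (0.70 log units; beyond the scatter), when methyl replaces (oxiran-2-yl)methoxy. That modest step shows that the number can move when this group changes. However, it involves a much larger group than trifluoromethyl, and no measured compound carries trifluoromethyl, so the data give no firm direction. The expectation is therefore no step beyond the scatter, with only a slight lean towards a lower number. The estimate amounts to a 1.1-fold lower number from compound 2 to compound 3 (0.06 log units; within the scatter), an expected change that remains small. For compound 3 the expected value is 350 nM, with an estimated range of 120 nM to 1000 nM.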

Compound 3, concentration for 50% growth inhibition: 800 nM
Compound 3: the middle estimate sits 2.3-fold (0.36 log units) below what was measured; low and high end bracket the measured number.
By their numbers in this assay, from the lowest: compound 1; then compounds 2 and 3 (each within the scatter of the next).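

In this assay, trifluoromethyl in place of methyl on this aromatic carbon gives a 2.0-fold higher number from compound 2 to compound 3 (0.30 log units; within the scatter) and so cannot be told apart from the methyl compound, even though the entering group has 4 heavy atoms where methyl has 1. This means that at this position, para to a large group, the two small groups without hydrogen-bond donors or acceptors read alike, whereas the earlier pair alone could not show how a second small group would behave. Compound 1 now stands apart from both, since the step to trifluoromethyl is a 10-fold higher number from compound 1 to compound 3 (1.00 log units; beyond the scatter) and is beyond the scatter, like the step to methyl, but nothing measured here offers a reason for this gap.

The compounds shown leave open whether compound 1 owes its lower number to the whole (oxiran-2-yl)methoxy group or to one part of it, which a plain methoxy group or a longer ether chain without the oxirane ring would help to separate. As far as these compounds go, it also remains open whether an amine or a carboxylic acid on this carbon would read like compound 1 or like compound 2 and compound 3.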